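A Methoxy Group in Place of Hydrogen on Compound 1

This account rests on a few compounds, and the source may have more. Where it says the series, first, only, none or still open, it means among the compounds named here.

In a functional assay on Hep cells (Homo sapiens) for cytotoxicity, read by sulforhodamine B assay, with a stated time of 48 h (a higher number here means a weaker inhibitor, a lower number a stronger inhibitor), compound 1 `CC1=C(/C=C/C(=O)/C=C/c2ccccc2)C(C)(C)CCC1` gives 62200 nM, the higher of the two numbers shown, while compound 2 `CC1=C(/C=C/C(=O)/C=C/c2ccc([N+](=O)[O-])cc2)C(C)(C)CCC1` gives 55500 nM; the one step between them, a 1.1-fold lower number from compound 1 to compound 2 (0.05 log units; within the scatter), lies within the scatter. Compound 3 `COc1ccccc1/C=C/C(=O)/C=C/C1=C(C)CCCC1(C)C` differs from compound 1 by methoxy in place of hydrogen on an aromatic carbon. Among the compounds with values here, the only step that bears on a change of this kind is the one from compound 1 to compound 2, and it stayed within the scatter, so no step beyond the scatter is expected in this assay. Compound 3 is therefore estimated at 55000 nM, between 25000 nM and 130000 nM, which means a 1.1-fold lower number from compound 1 to compound 3 (0.05 log units; within the scatter).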

Compound 3, half-maximal inhibitory concentration: 38900 nM
The estimate for compound 3 lay 1.4-fold (0.15 log units) above the measured number, within the range that was stated.
By their numbers in this assay, from the lowest: compounds 3, 2 and 1 (each within the scatter of the next).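

In this assay, methoxy in place of hydrogen on an aromatic carbon, ortho to a large group, gives a 1.6-fold lower number from compound 1 to compound 3 (0.20 log units; within the scatter). Like nitro on the aromatic ring of compound 2, methoxy at this place on compound 3 leaves the number within the scatter of compound 1, so neither change shown moves it measurably. No evidence here bears on this result. Going by these compounds, whether an amine or a carboxylic acid on this same aromatic carbon would give a step beyond the scatter remains open, as does the effect of methoxy on another carbon of the ring.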